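The source may hold more compounds than are shown below. What is called first, only, known or untested is meant among the compounds shown, and "the series" means these compounds.

Compounds measured in an ADME assay on HepG2 cells (Homo sapiens) for cytotoxicity, with a stated time of 72 h; a lower number here means that less compound is needed, a higher number that more compound is needed for the effect:

compound 1 `Cc1cc(NC(=O)Nc2ccc(Cl)c(Cl)c2)c2ccccc2n1` gives 17000 nM
compound 2 `COc1ccc(NC(=O)Nc2cc(C)nc3ccccc23)cc1Cl` gives > 25000 nM
compound 3 `Cc1cc(NC(=O)Nc2cccnc2)c2ccccc2n1` gives > 25000 nM

Compound 3 gives no number and stands only at a limit of > 25000 nM in this assay as its reading. Compound 2 is likewise only a limit of > 25000 nM as its reading. Thus the limit of > 25000 nM in this assay, at which 2 of the 3 values shown sit, leaves compound 1 as the only one with a number.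

Compound 4 `Cc1cc(NC(=O)Nc2cccc(Cl)c2)c2ccccc2n1` is reached from compound 3 by one change: 3-chlorophenyl in place of pyridin-3-yl on an amide-type nitrogen that is, 3-chlorophenyl in place of pyridin-3-yl on an amide-type nitrogen. For the measured compounds named here, the one measured step that bears on this is an at least 1.4-fold higher number from compound 1 to compound 2 (0.16 log units; that floor lies within the scatter) for methoxy in place of chloro on an aromatic carbon. Going by the values given here, it is a different change and sets only a floor, so it supports no large step. Compound 1 carries chloro and reads 17000 nM as a number. Compound 2 also carries chloro, however, so chloro does not separate numbers from limits here.

The expected change is an at least 1.1-fold lower number from compound 3 to compound 4 (0.05 log units; that floor lies within the scatter) and it is not expected to go beyond the scatter, though a lower number is the likelier direction. Compound 4 is estimated at 22000 nM with an expected range from 12000 nM to 40000 nM in this assay and may also read only as a limit.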

Compound 4, half-maximal effective concentration: 19000 nM
Compound 4: the middle estimate sits 1.2-fold (0.06 log units) above what was measured; the measured number falls inside the stated range.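

The change from pyridin-3-yl to 3-chlorophenyl on an amide-type nitrogen turns a limit into a number in this assay, giving an at least 1.3-fold lower number from compound 3 to compound 4 (0.11 log units; that floor lies within the scatter), so the size of this step is known only as a floor. The step for hydrogen in place of methoxy on an aromatic carbon is an at least 1.3-fold lower number from compound 2 to compound 4 (0.11 log units; that floor lies within the scatter), and both steps remain floors because two of the readings are limits and not numbers: the limit of > 25000 nM in this assay, at which 2 of the 4 values shown sit. For the compounds shown here, the one step between two true numbers is a 1.1-fold higher number from compound 1 to compound 4 (0.05 log units; within the scatter), for hydrogen in place of chloro on an aromatic carbon, so a single chloro on the aromatic ring is the only part of this series whose effect can be sized, and that effect does not go beyond the scatter.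

The compounds shown leave open how the reading would respond to an amine or a carboxylic acid in place of the chloro of compound 4. They also leave open whether any group on the amide-type nitrogen can give a step beyond the scatter, or whether the shared core sets the level of these readings.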